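The compounds below may be only part of what the source reports. "The series", "measured", "known", "first", "only" and "open" are said of these compounds alone.

Compound 1 `COc1ccccc1Cn1cc(C(=O)NCCCCN2CCc3cc(OC)c(OC)cc3C2)nn1` and compound 2 `COc1ccc(Cn2cc(C(=O)NCCCCN3CCc4cc(OC)c(OC)cc4C3)nn2)cc1` share one core, while compound 3 `COc1ccccc1Cn1cc(-c2ccc(C(=O)NCCCCN3CCc4cc(OC)c(OC)cc4C3)cc2)nn1` is built on another; the difference between the two cores is not broken down here. In an assay on membranes from brain for displacement of a labelled ligand from Sigma non-opioid intracellular receptor 1 (Cavia porcellus), read by scintillation counting, with a stated time of 90 min (on this read-out lower numbers stand for stronger inhibition and higher numbers for weaker inhibition), compound 1 gives 20600 nM, and compound 2 gives 3350 nM. The change that separates them, (4-methoxyphenyl in place of 2-methoxyphenyl on a saturated chain carbon bound to an aromatic nitrogen), brings a 6.1-fold lower number from compound 1 to compound 2 (0.79 log units; beyond the scatter). Compound 3 falls between the two: in this assay compound 3 gives 8580 nM, a higher number than compound 2 shows and a lower one than compound 1 shows.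

Compound 4 `COc1ccc(Cn2cc(-c3ccc(C(=O)NCCCCN4CCc5cc(OC)c(OC)cc5C4)cc3)nn2)cc1` has not yet been measured. It stands to compound 3 exactly as compound 2 stands to compound 1, through the same change, (4-methoxyphenyl in place of 2-methoxyphenyl on a saturated chain carbon bound to an aromatic nitrogen). Whether that change carries the same weight on the core of compound 3 cannot be checked against the measured compounds, since it has been measured only once, on the core of compound 1. The expectation for compound 4 therefore rests on that single step. A step of roughly the same size is expected, a 5.0-fold lower number from compound 3 to compound 4 (0.70 log units; beyond the scatter), because the same change produced a 6.1-fold lower number from compound 1 to compound 2 (0.79 log units; beyond the scatter) on the other core, with the span kept wide to allow for the core being different. On that footing compound 4 is expected to give 1700 nM in this assay, with a likely range from 550 nM to 5500 nM.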

Compound 4, inhibition constant: 12600 nM
For compound 4 the middle estimate is 7.4-fold (0.87 log units) below the measured one, and the stated range ends below it.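

In this assay, the change to 4-methoxyphenyl in place of 2-methoxyphenyl gives a 1.5-fold higher number from compound 3 to compound 4 (0.17 log units; within the scatter), and so it does not repeat on this second core what it did on the first, as the two steps set side by side make plain: the same change on two cores in this assay, a 6.1-fold lower number (0.79 log units; beyond the scatter) from compound 1 to compound 2 and a 1.5-fold higher number (0.17 log units; within the scatter) from compound 3 to compound 4, 9.0-fold (0.96 log units) apart, beyond the scatter of two such steps This shows that, within the four compounds here, the size of the step measured on the core of compound 1 cannot simply be carried over to the core of compound 3, so the effect of this change depends on the core it sits on. It does not show which part of the difference between the two cores is responsible, why the two steps part, or how the change would behave on any third core, as the comparison rests on a single pair of compounds for each core.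

The compounds shown leave open whether a plain benzyl group, or a benzyl group bearing a chlorine or a hydroxyl in place of the methoxy, would follow the same core dependence. They also leave open whether that dependence would persist with a longer chain leading to the amine.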